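The compounds below may be only part of what the source reports. "The series", "measured", "known", "first", "only" and "open" are said of these compounds alone.

Compound 1 `COc1cccc(-c2c(C)n(Cc3ccccc3F)c3nc(C(C)(C)C)c(CN(C)Cc4ccccn4)n3c2=O)c1` gives 11 nM in an assay on isolated protein for binding affinity to Gonadotropin-releasing hormone receptor (Homo sapiens); a lower number here means a stronger inhibitor, a higher number a weaker inhibitor. Compound 2 `COC(=O)C(C)(C)c1nc2n(Cc3ccccc3F)c(C)c(-c3cccc(OC)c3)c(=O)n2c1CN(C)Cc1ccccn1` gives 4.2 nM.

For the measured compounds named here, compound 2 holds the lower of the two numbers; the only measured step, a 2.6-fold lower number from compound 1 to compound 2 (0.42 log units; beyond the scatter), separates it from compound 1. Compound 3 `COC(=O)C(C)(C)c1nc2n(Cc3ccccc3F)c(C)c(-c3cccc(OC)c3)c(=O)n2c1CN1CCC(c2ccccc2)CC1` differs from compound 2 by 4-phenylpiperidin-1-yl in place of methyl((pyridin-2-yl)methyl)amino on a saturated chain carbon bound to an aromatic carbon. Going by the values given here, no measured step touches this part of the shared core, so the single step from compound 1 to compound 2 offers no guide to it. Without such a guide, compound 3 is expected to stay near compound 2, with a step of a 1.4-fold higher number from compound 2 to compound 3 (0.15 log units; within the scatter) and a wide range. The estimate for compound 3 is 6 nM, between 1.5 nM and 30 nM.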

Compound 3, inhibition constant: 5100 nM
Compound 3: middle estimate off by 850-fold (2.93 log units), on the low side; measured number outside the range, above it.
By their numbers in this assay, from the lowest: compound 2; then compound 1; then compound 3.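

The change to 4-phenylpiperidin-1-yl gives a 1200-fold higher number from compound 2 to compound 3 (3.08 log units; beyond the scatter) in this assay, so the group on this saturated chain carbon matters far more to the number than the earlier change did, which gave a 2.6-fold lower number from compound 1 to compound 2 (0.42 log units; beyond the scatter). No measurement here accounts for the weakening.

The swap replaces the whole group at once, so the compounds leave open which part of it matters, the open chain or the nitrogen-containing aromatic ring. Benzyl(methyl)amino and 4-(pyridin-2-yl)piperidin-1-yl, each changing only one of these parts, would help to separate them.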